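Replacing the fluorophenyl group: compound 3 to compound 4

This account rests on a few compounds, and the source may have more. Where it says the series, first, only, none or still open, it means among the compounds named here.

Of the compounds shown here, three have been measured in an assay on HEK293 cells for activation of Kir3.1/Kir3.2 (Homo sapiens), read by thallium flux; a lower number here means that less compound is needed, a higher number that more compound is needed for the effect. Compound 1 `Cc1cc(NC(=O)Cn2nnc(-c3ccccc3)n2)n(C2CCC(F)(F)CC2)n1` gives 84 nM in this assay. Compound 3 `Cc1cc(NC(=O)Cn2nnc(-c3ccccc3F)n2)n(C2CCCCC2)n1` gives 187 nM in this assay and so holds the higher of the two numbers; its nearest neighbour is compound 1, whose number sits lower by a gap beyond the usual scatter. Compound 2 `CC1(c2cc(NC(=O)Cn3nnc(-c4ccccc4)n3)n(C3CCCCC3)n2)CC1` sits at the limit of > 10000 nM in this assay, at which 1 of the 3 values shown sits, a limit rather than a number, reported as > 10000 nM. For the measured compounds named here, no two measured compounds differ in a single place, so no measured step is available to set the size of a change.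

Compound 4 `Cc1cc(NC(=O)Cn2nnc(-c3ccc(C(F)(F)F)cc3)n2)n(C2CCCCC2)n1` has not yet been measured. It differs from compound 3 in one place: 4-(trifluoromethyl)phenyl in place of 2-fluorophenyl on an aromatic carbon. Going by the values given here, with no measured step on this position to lean on, the outcome is open; a modest rise in the number, or none beyond the scatter, is expected. Compound 4 is estimated to give about 400 nM in this assay, within 100 nM to 2500 nM. The expected step is a 2.1-fold higher number from compound 3 to compound 4 (0.33 log units; beyond the scatter).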

Compound 4, half-maximal effective concentration: 241 nM
Compound 4: middle estimate off by 1.7-fold (0.22 log units), on the high side; the range from low to high includes it.
By their numbers in this assay, from the lowest: compound 1; then compounds 3 and 4 (each within the scatter of the next). At a limit, above all of these: compound 2.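

In this assay, for the compounds shown here, 4-(trifluoromethyl)phenyl in place of 2-fluorophenyl on the aromatic carbon of the five-membered ring gives a 1.3-fold higher number from compound 3 to compound 4 (0.11 log units; within the scatter), the first single-place step, and it shows that this position carries either group with the two values lying within the scatter of each other. The step joins the loss of the fluorine with the gain of the trifluoromethyl and does not separate the two. No measurement at hand bears on why the two groups read alike.

Open, as far as these compounds go, is how this position responds to a group of another kind, such as a phenyl ring bearing an amine or a carboxylic acid. Also open, from the compounds shown here alone, is whether the fluorine and the trifluoromethyl each read the same when placed alone at other carbons of the phenyl ring.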